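The source may report more compounds than this note shows. Statements on the series, on what has been measured and on what is new or still open speak of the compounds shown alone.

In a functional assay on MCF7 cells (Homo sapiens) for inhibition, read by sulforhodamine B assay (on this read-out higher numbers stand for weaker inhibition of growth and lower numbers for stronger inhibition of growth), three compounds have been measured so far. Compound 1 (`Cc1ccc2[nH]c(-c3ccc(-c4ccc(-c5cccc(Cl)c5)cc4)cc3)nc2c1`) gives 1210 nM, compound 2 (`COc1ccc(-c2ccc(-c3ccc(-c4nc5cc(C)ccc5[nH]4)cc3)cc2)cc1OC`) gives 190 nM, and compound 3 (`Fc1ccc(-c2ccc(-c3ccc(-c4nc5ccccc5[nH]4)cc3)cc2)cc1`) gives 36200 nM, the highest of the three numbers and so the weakest inhibition of growth. Compound 4 (`FC(F)(F)Oc1ccc(-c2ccc(-c3ccc(-c4nc5ccccc5[nH]4)cc3)cc2)cc1`) differs from compound 3 in one place: trifluoromethoxy in place of fluoro on an aromatic carbon. Put simply, trifluoromethoxy takes the place of fluoro on an aromatic carbon, para to a large group.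

Among the measured compounds shown here, no measured step makes this exact swap. The closest guide is a 6.4-fold lower number from compound 1 to compound 2 (0.80 log units; beyond the scatter), where 3,4-dimethoxyphenyl replaces 3-chlorophenyl on an aromatic carbon. That step shows that one exchange of this kind can move the number beyond the scatter, but it says little about this particular change. Compound 3 stands at 36200 nM, and the two other measured compounds both give far lower numbers, so a lower number is the more likely direction. The expected change is a 6.0-fold lower number from compound 3 to compound 4 (0.78 log units; beyond the scatter), a rough estimate. Compound 4 is estimated at 6000 nM, with an expected range of 800 nM to 40000 nM.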

Compound 4, concentration for 50% growth inhibition: 38400 nM
Beside the measured number, compound 4's estimate is 6.4-fold (0.81 log units) below it, and the stated range covers the measured number.
By their numbers in this assay, from the lowest: compound 2; then compound 1; then compounds 3 and 4 (each within the scatter of the next).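

In this assay, trifluoromethoxy in place of fluoro on this aromatic carbon, para to a large group, gives a 1.1-fold higher number from compound 3 to compound 4 (0.03 log units; within the scatter) and so no readable difference between the two compounds. Among the compounds shown here, the step adds four heavy atoms and a hydrogen-bond acceptor, yet this larger group leaves the number within the scatter, whereas the only earlier step showed a change beyond it at a different exchange of groups. Nothing measured here offers an explanation for this result.

On these data alone, whether a group of another kind at the same place, such as an amine or a carboxylic acid, would move the number beyond the scatter remains open. As far as these compounds go, it is also open whether the same exchange would behave alike on the core of compound 1, which carries a methyl group that compound 3 and compound 4 lack.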